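The source may hold more compounds than are shown below. What is called first, only, known or untested is meant among the compounds shown, and "the series" means these compounds.

Three compounds have been measured in an assay for binding affinity to dual specificity mitogen-activated protein kinase kinase 4 (Homo sapiens), read by KINOMEscan, tested at 100 nM; a higher number here means a weaker effect of the compound at the concentration tested, a lower number a stronger effect:
Compound 1, `CCCS(=O)(=O)Nc1ccc(F)c(C(=O)c2n[nH]c3ncc(-c4cccc(Cl)c4)cc23)c1F`, gives 40%.
Compound 2, `CCCS(=O)(=O)Nc1ccc(F)c(C(=O)c2n[nH]c3ncc(-c4ccc(OC)cc4)cc23)c1F`, gives 4.2%.
Compound 3, `CCCS(=O)(=O)Nc1ccc(F)c(C(=O)c2n[nH]c3ncc(-c4ccc(C)c(C)c4)cc23)c1F`, gives 20%.

All three share the same core and differ only in the aromatic ring attached to it. Compound 1 has the highest number of the three, which here means the weakest effect at the tested concentration. Its nearest neighbour is compound 3, with a number 20 percentage points lower from compound 1 to compound 3 (beyond the scatter), and the furthest is compound 2, with a number 35.8 percentage points lower from compound 1 to compound 2 (beyond the scatter). Between the two other rings, a number 15.8 percentage points higher from compound 2 to compound 3 (beyond the scatter).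

Compound 4, `CCCS(=O)(=O)Nc1ccc(F)c(C(=O)c2n[nH]c3ncc(-c4ccc(C(C)(C)C)cc4)cc23)c1F`, has not yet been measured. It departs from compound 1 in the same place as compounds 2 and 3 do: 4-(tert-butyl)phenyl in place of 3-chlorophenyl on an aromatic carbon. Both measured exchanges of the 3-chlorophenyl ring lowered the number beyond the scatter, so a lower number, meaning a stronger effect, is expected for compound 4 as well. The 4-(tert-butyl)phenyl ring matches neither the 4-methoxyphenyl nor the 3,4-dimethylphenyl ring, so the size of the drop is uncertain and is taken between the two measured ones. For compound 4 the expected step is a number 25 percentage points lower from compound 1 to compound 4 (beyond the scatter). The estimate for compound 4 is 15%, with a range from 3% to 35%.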

Compound 4, a percentage reported as activity, at one concentration (the size of the read-out at that concentration, not a potency): 46%
Beside the measured number, compound 4's estimate is 31 percentage points below it, and the stated range ends below it.
By their numbers in this assay, from the lowest: compound 2; then compound 3; then compounds 1 and 4 (each within the scatter of the next).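

Going by these compounds alone, until this result, each replacement of the 3-chlorophenyl ring had lowered the number in this assay, but the 4-(tert-butyl)phenyl ring gives a number 6 percentage points higher from compound 1 to compound 4 (within the scatter), so changing the ring at this position does not by itself bring a stronger effect. What the phenyl ring carries matters a great deal: tert-butyl in place of methoxy gives a number 41.8 percentage points higher from compound 2 to compound 4 (beyond the scatter), and the 4-(tert-butyl)phenyl ring in place of the 3,4-dimethylphenyl ring gives a number 26 percentage points higher from compound 3 to compound 4 (beyond the scatter), so compounds 2 and 3 keep a stronger effect than compound 4 while all three differ from compound 1 in this one place. No measurement at hand accounts for these differences.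

The compounds shown leave open how the number moves along a series of groups on the same ring, for instance ethyl or isopropyl in place of tert-butyl, or ethoxy or hydroxy in place of methoxy. They also leave open what an amine or a carboxylic acid on the phenyl ring would do, and whether a chlorine alone in the place of the tert-butyl group would behave like the 3-chlorophenyl ring of compound 1.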